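Replacing the amide group of compound 3

The compounds below may be only part of what the source reports. "The series", "measured", "known", "first", "only" and "open" are said of these compounds alone.

Values in a functional assay on KETR3 cells (Homo sapiens) for inhibition, read by MTT assay, with a stated time of 120 h; a higher number here means a weaker inhibitor, a lower number a stronger inhibitor:
- compound 1 `C/C(=C\c1ccc(NC(=O)Nc2ccc(Cl)c(C(F)(F)F)c2)cc1)C(=O)NC(C)c1ccccc1`: > 50000 nM (a limit)
- compound 2 `CC1CN(C(=O)c2ccc(-c3ccc(NC(=O)Nc4ccc(Cl)c(C(F)(F)F)c4)cc3)cc2)CC(C)O1`: 41900 nM
- compound 3 `CC(NC(=O)/C=C/c1ccc(NC(=O)Nc2ccc(Cl)c(C(F)(F)F)c2)cc1)c1ccccc1`: 21200 nM

Of the compounds shown here, three sharing a urea-bearing core have been measured in this assay. Compound 1 reports only a limit, > 50000 nM, and not a number. The same holds for one value in this small set: the limit of > 50000 nM in this assay, at which 1 of the 3 values shown sits.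

Compound 3 gives 21200 nM and compound 2 gives 41900 nM, two numbers that lie within the scatter of each other. Compound 3 therefore stands level with compound 2 on the numbers available.

The next compound is compound 4 `CC1CN(C(=O)/C=C/c2ccc(NC(=O)Nc3ccc(Cl)c(C(F)(F)F)c3)cc2)CC(C)O1`, which differs from compound 3 at a single place. The change is 2,6-dimethylmorpholin-4-yl in place of (1-phenylethyl)amino on a carbonyl carbon, with 2,6-dimethylmorpholin-4-yl in place of (1-phenylethyl)amino on a carbonyl carbon. For the measured compounds named here, no measured pair isolates this change. Compound 2 also carries 2,6-dimethylmorpholin-4-yl on a carbonyl carbon, and compound 2 gives 41900 nM, so no large gain in this assay is expected. The expected step, a 1.4-fold higher number from compound 3 to compound 4 (0.15 log units; within the scatter), is estimated to stay within the scatter, leaning slightly towards a higher number. A result at the limit of the assay remains possible. For compound 4 the estimated value is 30000 nM, with an expected range of 12000 nM to 50000 nM.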

Compound 4, half-maximal inhibitory concentration: > 50000 nM
Compound 4 gave a limit, no number; the forecaster's own chance of this, stated with the estimate: 30%; middle value at least 1.6-fold (0.22 log units) away from the limit.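

The carbonyl carbon bearing the double-bonded chain carbon proves to be a position where this change matters in this assay. Putting 2,6-dimethylmorpholin-4-yl in place of (1-phenylethyl)amino, which takes away the hydrogen-bond donor and the aromatic ring of the leaving group, gives an at least 2.3-fold higher number from compound 3 to compound 4 (0.37 log units; beyond the scatter). Compound 4 reports a limit, > 50000 nM, and not a number. Going by these compounds, the true size of the step therefore stays unknown, and limits now take a larger share of this small set: the limit of > 50000 nM in this assay, at which 2 of the 4 values shown sit.

The compounds shown leave open whether the amide hydrogen or the aromatic ring of the leaving group counts for more in this step. They also leave open how a benzylamino group or a piperazine ring on the same carbonyl carbon would read in this assay.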